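The compounds below may be only part of what the source reports. "The series", "measured", "known", "first", "only" and "open" are said of these compounds alone.

Compound 2 `O=S(=O)(c1ccccc1)n1ccc2ccc(-c3ccncc3)cc21` and compound 1 `O=S(=O)(c1ccccc1)n1ccc2ccc(N3CCCCC3)cc21` share one core. In an assay on isolated protein for displacement of a labelled ligand from 5-hydroxytryptamine receptor 6 (Homo sapiens), read by scintillation counting, with a stated time of 1 h (a higher number here means a weaker inhibitor, a lower number a stronger inhibitor), compound 2 gives 38 nM, the lowest of the two numbers. Compound 1 gives 403 nM, and an 11-fold lower number from compound 1 to compound 2 (1.03 log units; beyond the scatter). Compound 3 `CCCCS(=O)(=O)n1ccc2ccc(-c3ccncc3)cc21` differs from compound 2 by butyl in place of phenyl on a sulfonyl sulfur. Among the compounds with values here, no measured step touches that sulfonyl sulfur: the only known step concerns a change on an aromatic carbon, a different place, so it offers no direct guide. The change in compound 3 is therefore expected to give a 3.9-fold higher number from compound 2 to compound 3 (0.60 log units; beyond the scatter), with wide uncertainty. The estimate for compound 3 is 150 nM, expected to fall between 30 nM and 800 nM.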

Compound 3, inhibition constant: 1150 nM
For compound 3 the middle estimate is 7.7-fold (0.88 log units) below the measured one; measured number above the stated range.
By their numbers in this assay, from the lowest: compound 2; then compound 1; then compound 3.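

In this assay the sulfonyl sulfur proves to be a sensitive position, not only the aromatic carbon: there is a 30-fold higher number from compound 2 to compound 3 (1.48 log units; beyond the scatter) when butyl, a chain with no ring, takes the place of the phenyl ring. Nothing available explains why this swap weakens binding so strongly. 

Still open, as far as these compounds go, is whether a shorter chain such as methyl, a phenyl ring carrying a fluorine or an amine on the sulfonyl sulfur would keep the number low. Also open, from the compounds shown here alone, is whether the same swap would have a similar effect alongside the piperidin-1-yl group of compound 1.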